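This account rests on a few compounds, and the source may have more. Where it says the series, first, only, none or still open, it means among the compounds named here.

Compound 1, `CCOc1ccc(NC(=O)O/N=C/c2ccccc2)cc1`, gives 81 nM in an assay on H4 cells for inhibition of Fatty-acid amide hydrolase 1 (Homo sapiens); a lower number here means a stronger inhibitor, a higher number a weaker inhibitor.
Compound 2, `CCCCCCCCCCOc1ccc(NC(=O)O/N=C/c2ccccc2)cc1`, gives 0.35 nM in this assay.
Compound 3, `CCCCCCCCCCCCOc1ccc(NC(=O)O/N=C/c2ccccc2)cc1`, gives 2.4 nM in this assay.

Among these three, compound 1 has the highest number and is thus the weakest inhibitor. Lengthening the chain attached to the oxygen on an aromatic ring brings a large gain, a 230-fold lower number from compound 1 to compound 2 (2.36 log units; beyond the scatter) and a 34-fold lower number from compound 1 to compound 3 (1.53 log units; beyond the scatter), while between the two longer chains there is a modest loss, a 6.9-fold higher number from compound 2 to compound 3 (0.84 log units; beyond the scatter).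

Compound 4, `CCOc1ccc(NC(=O)O/N=C/c2ccc(F)cc2)cc1`, keeps the short chain of compound 1 and differs from it only by fluoro in place of hydrogen on an aromatic carbon. Among the measured compounds shown here, none of the measured steps touches this ring; all three concern the chain on the other side of the molecule, so none of them bears directly on this change. With no measured guidance for this position, the expected step from compound 1 to compound 4 in this assay is a 1.2-fold lower number from compound 1 to compound 4 (0.10 log units; within the scatter), that is, nothing beyond the scatter. Compound 4 is therefore estimated at 65 nM, with a range from 20 nM to 220 nM.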

Compound 4, half-maximal inhibitory concentration: 46 nM
Estimate against measurement, compound 4: 1.4-fold (0.15 log units) above; the measured number falls inside the stated range.
By their numbers in this assay, from the lowest: compound 2; then compound 3; then compounds 4 and 1 (each within the scatter of the next).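

Unlike the earlier steps, all of which changed the chain, this one changes the phenyl group, and in this assay it gives a 1.8-fold lower number from compound 1 to compound 4 (0.25 log units; within the scatter). Fluoro can therefore take this place, para to a large group, without a change beyond the scatter, whereas all the chain steps lay beyond it. No measurement shown offers an explanation for this result.

Going by these compounds, it remains open whether a larger group in the same place, such as methoxy or a carboxylic acid, would also leave the number within the scatter. On these data alone, it is also open whether the swap of phenyl to 4-fluorophenyl would give a similar result on the longer chain of compound 2, where the number is already much lower.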